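The source may report more compounds than this note shows. Statements on the series, on what has been measured and on what is new or still open speak of the compounds shown alone.

Of the compounds shown here, three share one core and have been tested in a functional assay on COLO 205 cells (Homo sapiens) for cytotoxicity, read by MTT assay, with a stated time of 72 h; on this read-out lower numbers stand for stronger inhibition and higher numbers for weaker inhibition. Compound 1 `COc1ccc(/C=C/C(=O)Nc2cc(C(=O)c3cc(OC)c(OC)c(OC)c3)ccc2OC)cc1` gives 10900 nM. Compound 2 `C#CCOc1cccc(/C=C/C(=O)Nc2cc(C(=O)c3cc(OC)c(OC)c(OC)c3)ccc2OC)c1` gives 13400 nM, and compound 3 `COc1ccc(C(=O)c2cc(OC)c(OC)c(OC)c2)cc1NC(=O)/C=C/c1cccc(OC(F)(F)F)c1` gives 7900 nM. Among these three numbers compound 1 holds the second highest, but the three values sit close together: the steps of a 1.2-fold higher number from compound 1 to compound 2 (0.09 log units; within the scatter), a 1.4-fold lower number from compound 1 to compound 3 (0.14 log units; within the scatter) and a 1.7-fold lower number from compound 2 to compound 3 (0.23 log units; within the scatter) are all within the scatter, so no order among the three can be claimed.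

Compound 4 `COc1ccc(/C=C/C(=O)Nc2cc(C(=O)c3cc(OC)c(OC)c(OC)c3)cc(OC)c2OC)cc1` has not yet been measured. It differs from compound 1 in a single place: methoxy in place of hydrogen on an aromatic carbon. Among the compounds with values here, none of the measured steps touches this part of the molecule; each of them alters a different ring, and none of them moved the read-out beyond the scatter. Within the data shown here, the only guide is therefore compound 1 itself. Compound 4 is expected to land close to it, with a step of a 1.0-fold higher number from compound 1 to compound 4 (0.00 log units; within the scatter) expected. The estimate for compound 4 in this assay is 11000 nM, within a range from 4500 nM to 27000 nM.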

Compound 4, half-maximal inhibitory concentration: 4800 nM
The estimate for compound 4 lay 2.3-fold (0.36 log units) above the measured number; the range from low to high includes it.
By their numbers in this assay, from the lowest: compounds 4, 3, 1 and 2 (each within the scatter of the next, the first and the last beyond it).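

In this assay, within the data shown here, methoxy in place of hydrogen on this aromatic carbon, ortho to a methoxy group and meta to two large groups, gives a modest step that is the first in this set to lie beyond the scatter (a 2.3-fold lower number from compound 1 to compound 4 (0.36 log units; beyond the scatter)). This position can therefore shift the read-out, whereas the earlier changes, made elsewhere in the molecule, all stayed within the scatter. No measurement at hand explains why the added methoxy has this effect.

Methoxy is the only group shown at this position, so it remains open whether a hydroxyl group, a fluorine atom or a longer chain such as ethoxy would move the number further, leave it unchanged or reverse the step. On these data alone, it is also open whether the added methoxy would give a similar step alongside the 3-(trifluoromethoxy)phenyl group of compound 3.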